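Triazole N-aryl variation in a diaryl urea series

The source may hold more compounds than are shown below. What is called first, only, known or untested is meant among the compounds shown, and "the series" means these compounds.

Measured in a toxicity assay on MRC5 cells (Homo sapiens) for inhibition, read by MTT assay, with a stated time of 72 h; a lower number here means a stronger inhibitor, a higher number a weaker inhibitor:
compound 1 `O=C(Nc1cccc(OCc2cn(-c3ccccc3)nn2)c1)Nc1ccc(Cl)c(C(F)(F)F)c1`: 18400 nM
compound 2 `COc1cccc(-n2cc(COc3cccc(NC(=O)Nc4ccc(Cl)c(C(F)(F)F)c4)c3)nn2)c1`: 8570 nM
compound 3 `O=C(Nc1cccc(OCc2cn(-c3ccccc3I)nn2)c1)Nc1ccc(Cl)c(C(F)(F)F)c1`: 21900 nM

Compound 2 gives the lowest number of the three; its steps to compound 1 and to compound 3 are both beyond the scatter, a 2.1-fold lower number from compound 1 to compound 2 (0.33 log units; beyond the scatter) and a 2.6-fold higher number from compound 2 to compound 3 (0.41 log units; beyond the scatter). Compound 1 and compound 3 sit within the scatter of each other, a 1.2-fold higher number from compound 1 to compound 3 (0.08 log units; within the scatter).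

Compound 4 `O=C(Nc1cccc(OCc2cn(-c3ccccc3C(F)(F)F)nn2)c1)Nc1ccc(Cl)c(C(F)(F)F)c1` differs from compound 2 by 2-(trifluoromethyl)phenyl in place of 3-methoxyphenyl on an aromatic nitrogen. Among the compounds with values here, the step that bears on it is the one from compound 2 to compound 3, where a 2-substituted phenyl also replaced 3-methoxyphenyl and the number rose modestly, a 2.6-fold higher number from compound 2 to compound 3 (0.41 log units; beyond the scatter). A similar modest rise is expected here, a 2.2-fold higher number from compound 2 to compound 4 (0.35 log units; beyond the scatter), placing compound 4 near compound 1 and compound 3. Compound 4 is estimated at 19000 nM, range 8000 nM to 45000 nM.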

Compound 4, half-maximal inhibitory concentration: 8230 nM
Compound 4: the middle estimate sits 2.3-fold (0.36 log units) above what was measured; the measured number falls inside the stated range.
By their numbers in this assay, from the lowest: compounds 4 and 2 (each within the scatter of the next); then compounds 1 and 3 (each within the scatter of the next).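

In this assay, 2-(trifluoromethyl)phenyl on the aromatic nitrogen and 3-methoxyphenyl are not separated (a 1.0-fold lower number from compound 2 to compound 4 (0.02 log units; within the scatter)), so the 2-iodophenyl result does not carry over to every 2-substituted phenyl. Trifluoromethyl in place of iodo on an aromatic carbon is a real step (a 2.7-fold lower number from compound 3 to compound 4 (0.43 log units; beyond the scatter)), as is trifluoromethyl in place of hydrogen (a 2.2-fold lower number from compound 1 to compound 4 (0.35 log units; beyond the scatter)). The identity of the substituent therefore matters here, with iodo the group that goes against any general lowering by substitution on this phenyl.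

What lies behind these steps has no supporting measurement here. As far as these compounds go, whether an amine or a carboxylic acid on this phenyl would take the number below that of compound 2 and compound 4 remains open.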